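Trimethoxyphenyl in place of methoxyphenyl on a shared core

The source may report more compounds than this note shows. Statements on the series, on what has been measured and on what is new or still open speak of the compounds shown alone.

Compound 1: `COc1cc(-c2cc(/C=C/C(=O)c3ccc(C)cc3)nc3cc(-c4ccccc4)nn23)cc(OC)c1OC` gives 50400 nM
Compound 2: `COc1ccc(C(=O)/C=C/c2cc(-c3ccc(OC)cc3)n3nc(-c4ccccc4)cc3n2)cc1` gives 36100 nM

In an ADME assay on HEK293 cells (Homo sapiens) for antiproliferative activity, read by MTT assay, with a stated time of 24 h (a lower number here means a stronger inhibitor, a higher number a weaker inhibitor), compound 1 gives 50400 nM and compound 2 gives 36100 nM. Compound 2 has the lowest of the two numbers, but its nearest neighbour, compound 1, lies within the usual scatter, so no order between the two can be claimed. Compound 3 is `COc1ccc(C(=O)/C=C/c2cc(-c3cc(OC)c(OC)c(OC)c3)n3nc(-c4ccccc4)cc3n2)cc1`, which differs from compound 2 in one place: 3,4,5-trimethoxyphenyl in place of 4-methoxyphenyl on an aromatic carbon. Compound 1 already carries the 3,4,5-trimethoxyphenyl group at a comparable position on the shared core, and both measured compounds sit in the same weak range, so no step beyond the scatter is expected. Compound 3 is estimated at 45000 nM, with a range from 15000 nM to 130000 nM. The expected step from compound 2 to compound 3 is therefore a 1.2-fold higher number from compound 2 to compound 3 (0.10 log units; within the scatter), within the scatter, because compound 1 gives 50400 nM and compound 2 gives 36100 nM.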

Compound 3, half-maximal inhibitory concentration: 79800 nM
Estimate against measurement, compound 3: 1.8-fold (0.25 log units) below; measured number inside the range.
By their numbers in this assay, from the lowest: compounds 2, 1 and 3 (each within the scatter of the next, the first and the last beyond it).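

In this assay, 3,4,5-trimethoxyphenyl in place of 4-methoxyphenyl on this aromatic carbon gives a 2.2-fold higher number from compound 2 to compound 3 (0.34 log units; beyond the scatter), a modest step and the only one shown that lies beyond the scatter, so this position does respond to the change. By contrast, methoxy in place of methyl on an aromatic carbon gives a 1.6-fold higher number from compound 1 to compound 3 (0.20 log units; within the scatter), which cannot be told apart from repeat scatter. No measurement shown bears on why the larger group gives the higher number.

The compounds shown leave open whether a plain phenyl, a 4-hydroxyphenyl or a 4-aminophenyl on this carbon would give a lower number than the 4-methoxyphenyl group. On these data alone, it also remains open whether the same step would appear with methyl in place of methoxy elsewhere on the molecule.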